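Methoxy to ethoxy at the assay limit

The source may hold more compounds than are shown below. What is called first, only, known or untested is meant among the compounds shown, and "the series" means these compounds.

In an ADME assay on HEK293 cells (Homo sapiens) for cytotoxicity, with a stated time of 72 h (on this read-out lower numbers stand for an effect already at smaller amounts and higher numbers for an effect only at larger amounts of compound), compound 2 `COc1ccc(/C=C/[C@@](C)(/C=C/c2ccc(O)cc2)CCC=C(C)C)cc1` gives > 36600 nM, which is a limit of the assay and not a number. Compound 1 `CCOC(=O)/C(C)=C/c1cc(/C=C/[C@](C)(/C=C/c2ccc(OC)cc2)CCC=C(C)C)ccc1O` gives > 36600 nM, also a limit. The evidence so far is therefore thin: the limit of > 36600 nM in this assay, at which 2 of the 2 values shown sit.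

Compound 3 `CCOc1ccc(/C=C/[C@@](C)(/C=C/c2ccc(O)cc2)CCC=C(C)C)cc1` differs from compound 2 by one small change, (methyl in place of hydrogen on a saturated chain carbon bound to an oxygen on an aromatic ring), turning 4-methoxyphenyl into 4-ethoxyphenyl. Going by the values given here, the only measured step is a step that the two limits leave unreadable from compound 1 to compound 2. It gives no size to carry over, but it does show compound 2 at the same limit as compound 1 after a much larger group, 2-(ethoxycarbonyl)prop-1-en-1-yl, gave way to hydrogen. A far smaller change is thus expected to give a step that the limit leaves unreadable from compound 2 to compound 3, with no shift beyond the scatter in either direction in this assay. The assay will most likely report only a limit again. For compound 3 the estimate is 40000 nM, with an expected range from 18000 nM to 80000 nM.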

Compound 3, half-maximal effective concentration: > 36600 nM
Compound 3 ended at the assay's limit (the forecaster's own chance of this, stated with the estimate: 75%); the middle value does not contradict the limit.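

Compound 2 and compound 3 both give only a limit in this assay, not a number, and the step between them, methoxy to ethoxy, cannot be read. Left open is whether compound 1, compound 2 or compound 3 affects these cells at larger amounts, as all the evidence remains a single point: the limit of > 36600 nM in this assay, at which 3 of the 3 values shown sit.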